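The source may report more compounds than this note shows. Statements on the series, on what has been measured and on what is new or still open speak of the compounds shown alone.

Working notes on the series. Three members are measured so far, and their structures stand beside them: compound 1 `CC(O)(CS(=O)(=O)c1ccc(Br)cc1)c1nc(-c2ccc([N+](=O)[O-])c(C(F)(F)F)c2)no1`, compound 3 `CC(O)(CS(=O)(=O)c1ccc(Br)cc1)c1nc(-c2ccccc2)no1` and compound 2 `CC(O)(CSc1ccc(Cl)cc1)c1nc(-c2ccccc2)no1`. In a functional assay on DU-145 cells (Homo sapiens) for cytotoxicity, read by MTT assay (a higher number here means a weaker inhibitor, a lower number a stronger inhibitor), compound 1 gives > 100000 nM, which is a limit of the assay and not a number. In this assay compound 3 gives > 100000 nM, again a limit of the assay. Among the measured compounds shown here, compound 2 gives 70700 nM in this assay and is the only member with a number rather than a limit, the other two sitting at the limit of > 100000 nM in this assay, at which 2 of the 3 values shown sit. For the measured compounds named here, no step between measured compounds that differ in one place is available, so nothing measured yet sizes a single change in this assay.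

Compound 4 `CC(O)(CSc1ccccc1)c1nc(-c2ccccc2)no1` is not yet measured. It differs from compound 2 by hydrogen in place of chloro on an aromatic carbon. Going by the values given here, with no measured step to lean on, the expected step is a 1.3-fold higher number from compound 2 to compound 4 (0.10 log units; within the scatter), which is not beyond the usual scatter, if anything toward a slightly weaker inhibitor. Compound 4 is estimated at 90000 nM in this assay, with a range from 40000 nM to 200000 nM.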

Compound 4, half-maximal inhibitory concentration: > 100000 nM
Compound 4: no number, only a limit; the forecaster's own chance of this, stated with the estimate: 35%; middle value at least 1.1-fold (0.04 log units) from the limit.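

Among the compounds shown here, replacing 4-chlorophenyl with phenyl gives the first measured single change, and in this assay it reads as an at least 1.4-fold higher number from compound 2 to compound 4 (0.15 log units; that floor lies within the scatter). As far as these compounds go, compound 4 gives a limit and not a number, so this step is only a floor: the true size of the change is unknown, and it may or may not lie beyond the scatter. For the compounds shown here, the loss of chloro at this position thus separates the only member with a number from a member at the limit, but the data show no more than that: the limit of > 100000 nM in this assay, at which 3 of the 4 values shown sit.

Open, from the compounds shown here alone, is whether a methoxy group or an amine in place of chloro on this aromatic carbon would give a number or a limit. Also open, going by these compounds, is whether chloro has the same effect on a different core.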